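The compounds below may be only part of what the source reports. "The series", "measured", "known", "first", "only" and "open" are said of these compounds alone.

For the measured compounds named here, in a functional assay on A549 cells (Homo sapiens) for cytotoxicity, read by MTT assay, with a stated time of 48 h (on this read-out lower numbers stand for stronger inhibition and higher numbers for weaker inhibition), compound 1 `Cc1ccc(S(=O)(=O)/N=C(/CCNC2=CC(=O)c3ccccc3C2=O)Nc2ccc(F)cc2)cc1` gives 9330 nM, the lowest of the two numbers measured so far. Compound 2 `Cc1ccc(S(=O)(=O)/N=C(/CCNC2=CC(=O)c3ccccc3C2=O)Nc2cccc(C(F)(F)F)c2)cc1` carries a different aryl group on the same amine nitrogen and in this assay gives 78500 nM. Going by the values given here, the one step measured is an 8.4-fold higher number from compound 1 to compound 2 (0.92 log units; beyond the scatter), where 3-(trifluoromethyl)phenyl stands in place of 4-fluorophenyl on an amine nitrogen.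

Compound 3 `Cc1ccc(S(=O)(=O)/N=C(/CCNC2=CC(=O)c3ccccc3C2=O)Nc2ccc(Cl)cc2Cl)cc1` has not yet been measured in this assay. It differs from compound 1 by 2,4-dichlorophenyl in place of 4-fluorophenyl on an amine nitrogen. Among the compounds with values here, no measured step covers this exact exchange; the only step that bears on it is the one from compound 1 to compound 2, which changes the same aryl group at the same place and shows that altering the aryl group on this amine nitrogen can weaken inhibition beyond the scatter. On that basis a step toward a higher number is expected for compound 3, though probably not as large as that seen for compound 2, giving an expected 2.1-fold higher number from compound 1 to compound 3 (0.33 log units; beyond the scatter). Compound 3 is therefore estimated at 20000 nM in this assay, with a range from 6000 nM to 70000 nM.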

Compound 3, half-maximal inhibitory concentration: 32900 nM
For compound 3 the middle estimate is 1.6-fold (0.22 log units) below the measured one, within the range that was stated.
By their numbers in this assay, from the lowest: compound 1; then compound 3; then compound 2.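

In this assay a second replacement of 4-fluorophenyl on this amine nitrogen also raises the number, with a 3.5-fold higher number from compound 1 to compound 3 (0.55 log units; beyond the scatter) in this case, so compound 1 remains the lowest of the three and both replacements shown weaken inhibition beyond the scatter. The two replacements are also separated from each other beyond the scatter, with a 2.4-fold lower number from compound 2 to compound 3 (0.38 log units; beyond the scatter) as the step between them, which shows that the size of the loss depends on which aryl group enters and that 2,4-dichlorophenyl gives up less than 3-(trifluoromethyl)phenyl. No measurement is at hand that would account for this order among the three aryl groups.

The compounds shown leave open how a plain phenyl, a 4-chlorophenyl or a 4-methoxyphenyl group on this amine nitrogen would stand, and so whether any aryl group here can give a lower number than 4-fluorophenyl does. They also leave open whether the same order of aryl groups would hold if the shared core carried a longer chain in place of its present one.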